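Anilide replacement in a piperidine carboxamide series: cytotoxicity

This account rests on a few compounds, and the source may have more. Where it says the series, first, only, none or still open, it means among the compounds named here.

Compound 1 `CSc1cccc(NC(=O)C2CCCN(C(=O)c3cc(C(F)(F)F)cc(C(F)(F)F)c3)C2)c1` gives 0% in an ADME assay on PC-3 cells (Homo sapiens) for cytotoxicity, read by WST assay, tested at 100 uM; a lower number here means less inhibition, a higher number more inhibition at the concentration tested (going by the name of the read-out). Compound 2 `Cc1nc(-c2cccc(C(=O)N3CCCC(C(=O)Nc4ccc(Cl)cc4)C3)c2)no1` gives 0% and compound 3 `COC(=O)c1cccc(C(=O)N2CCCC(C(=O)Nc3ccc(Cl)cc3)C2)c1` gives 0% in this assay, so compound 1 stands level with both on the numbers shown. Going by the values given here, the single measured step, no change at the digits printed from compound 2 to compound 3 (within the scatter), concerns the other aromatic ring of the shared core, not the anilide, and bears only loosely on the present change. Compound 4 `O=C(c1ccccc1)c1cccc(NC(=O)C2CCCN(C(=O)c3cc(C(F)(F)F)cc(C(F)(F)F)c3)C2)c1` differs from compound 1 by benzoyl in place of methylsulfanyl on an aromatic carbon. Among the compounds with values here, no measured step touches the anilide side, but with all three measured compounds at the floor of this assay, the expected step of a number 1 percentage points higher from compound 1 to compound 4 (within the scatter) is none beyond the scatter. Compound 4 is therefore estimated at 1%, within -9% to 14%.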

Compound 4, a percentage reported as inhibition, at one concentration (the size of the read-out at that concentration, not a potency): 0%
Compound 4: middle estimate off by 1 percentage points, on the high side; the range from low to high includes it.
By their numbers in this assay, from the lowest: compounds 1, 2, 3 and 4 (each within the scatter of the next).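

Working from the core of compound 1, the aromatic carbon meta to a large group accepts benzoyl, with 8 heavy atoms and a six-membered aromatic ring of carbon only, in place of methylsulfanyl, with 2 heavy atoms and no ring: this assay shows no change at the digits printed from compound 1 to compound 4 (within the scatter). Going by these compounds alone, this is the first measured step on the anilide side, and the larger group leaves the reading unmoved. Nothing available explains this result.

As far as these compounds go, whether an amine or a carboxylic acid on this carbon would give a different reading in this assay remains open.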